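This account rests on a few compounds, and the source may have more. Where it says the series, first, only, none or still open, it means among the compounds named here.

Measured so far:
Compound 1 `CCCCCCCCc1ccc(/C=C/C(=O)[C@H](CO)NC(C)=O)cc1` gives 70000 nM
Compound 2 `CC(=O)N[C@@H](CO)C(=O)/C=C/c1ccccc1` gives 42000 nM

In a functional assay on PC-12 cells (Rattus norvegicus) for antiproliferative activity, read by resazurin assay, with a stated time of 24 h (on this read-out higher numbers stand for weaker inhibition and lower numbers for stronger inhibition), compound 2 gives 42000 nM and compound 1 gives 70000 nM, so the two cannot be told apart. Within the data shown here, the only measured step is a 1.7-fold lower number from compound 1 to compound 2 (0.22 log units; within the scatter). Compound 3 `CC(=O)N[C@@H](CO)C(=O)/C=C/c1ccc(-c2ccccc2)cc1` is the next to be tested, and it differs from compound 2 as follows: phenyl in place of hydrogen on an aromatic carbon. Among the measured compounds shown here, the one measured step bears on this change only loosely, since it exchanges octyl for hydrogen on an aromatic carbon, and octyl is not phenyl. Even so, it offers no ground for expecting a step beyond the scatter in this assay, in either direction. The estimated step is a 1.1-fold higher number from compound 2 to compound 3 (0.03 log units; within the scatter). For compound 3 the expected value is 45000 nM, with an estimated range from 20000 nM to 100000 nM.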

Compound 3, half-maximal inhibitory concentration: 59000 nM
For compound 3 the middle estimate is 1.3-fold (0.12 log units) below the measured one, and the stated range covers the measured number.
By their numbers in this assay, from the lowest: compounds 2, 3 and 1 (each within the scatter of the next).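

In this assay, phenyl in place of hydrogen on the aromatic carbon gives only a small difference (a 1.4-fold higher number from compound 2 to compound 3 (0.15 log units; within the scatter)), so a second six-membered aromatic ring of carbon only, para to a large group, leaves the number within the scatter. Phenyl in place of octyl at the same place also stays within the scatter (a 1.2-fold lower number from compound 1 to compound 3 (0.07 log units; within the scatter)), so hydrogen, octyl and phenyl at this position now form a set of three that cannot be told apart, and neither a ring nor a chain separates itself from the unsubstituted compound 2. Nothing measured on these compounds speaks to why the numbers stay so close.

On these data alone, whether an amine or a carboxylic acid on this aromatic carbon would carry the number beyond the scatter remains open. So does whether any change in the shared core would do so.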